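The source may hold more compounds than are shown below. What is called first, only, known or untested is meant among the compounds shown, and "the series" means these compounds.

Compound 1 `O=C(Nc1cccc(-n2cc(-c3ccncc3)c(-c3cc(O)cc(Cl)c3)n2)c1)Nc1ccc(Cl)c(Cl)c1` — 95%
Compound 2 `COc1cc(Cl)cc(-c2nn(-c3cccc(NC(=O)Nc4ccc(Cl)c(Cl)c4)c3)cc2-c2ccncc2)c1` — 53%

Within the data shown here, in a functional assay on HCT-15 cells (Homo sapiens) for inhibition, read by sulforhodamine B assay, with a stated time of 48 h, tested at 0.1 uM (a lower number here means a stronger effect, a higher number a weaker effect of the compound at the concentration tested), compound 2 stands lowest of the two numbers; its only neighbour is compound 1, the one recorded step being a number 42 percentage points lower from compound 1 to compound 2 (beyond the scatter). Compound 3 `COc1cc(Cl)cc(-c2nn(-c3cccc(NC(=O)c4cccc(C(F)(F)F)c4)c3)cc2-c2ccncc2)c1` differs from compound 2 by 3-(trifluoromethyl)phenyl in place of (3,4-dichlorophenyl)amino on a carbonyl carbon. Among the measured compounds shown here, no measured step touches this part of the structure: the single recorded step concerns methyl in place of hydrogen on an oxygen on an aromatic ring. The expectation therefore rests on no comparison, and compound 3 is expected to give about 65%, between 30% and 100%. For compound 3 the expected step is a number 12 percentage points higher from compound 2 to compound 3 (beyond the scatter).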

Compound 3, a percentage reported as activity, at one concentration (the size of the read-out at that concentration, not a potency): 91%
The estimate for compound 3 lay 26 percentage points below the measured number; measured number inside the range.
By their numbers in this assay, from the lowest: compound 2; then compounds 3 and 1 (each within the scatter of the next).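

In this assay, the group on the carbonyl carbon, which the earlier step did not touch, also carries a large effect: 3-(trifluoromethyl)phenyl in place of (3,4-dichlorophenyl)amino gives a number 38 percentage points higher from compound 2 to compound 3 (beyond the scatter). This change removes the amino nitrogen and its hydrogen-bond donor and also replaces two chlorines with trifluoromethyl. Nothing at hand explains the step.

Which of these two differences matters remains open. A (3-(trifluoromethyl)phenyl)amino group or a 3,4-dichlorophenyl group on the carbonyl carbon would separate them.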